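The compounds below may be only part of what the source reports. "The series", "measured", "known", "first", "only" and "open" are said of these compounds alone.

Of the compounds shown here, two sharing one core have so far been tested in an ADME assay on HEK293 cells for agonist activity at Toll-like receptor 8 (Homo sapiens), read by a luciferase reporter, with a stated time of 6 h; on this read-out lower numbers stand for an effect already at smaller amounts and higher numbers for an effect only at larger amounts of compound. Compound 1 `CCCCNc1nc(N)nc2cccc(OCc3ccccc3)c12` gives 1.66 uM. Compound 2 `CCCCNc1nc(N)nc2cccc(OCc3cccnc3)c12` differs from it by pyridin-3-yl in place of phenyl on a saturated chain carbon bound to an oxygen on an aromatic ring, and in this assay compound 2 gives 0.53 uM. Going by the values given here, the only step known, a 3.1-fold lower number from compound 1 to compound 2 (0.50 log units; beyond the scatter), places compound 2 at the lowest of the two numbers, with compound 1 standing as the single neighbour above it.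

Compound 3 `CCCCNc1nc(N)nc2cccc(C(=O)NC(C)C)c12` is the next to be measured. Its change from compound 2 is isopropylcarbamoyl in place of (pyridin-3-yl)methoxy on an aromatic carbon. Among the compounds with values here, no measured step covers a change of this kind: the one step known kept the chain and its oxygen and exchanged only the ring at its end, whereas here the entire (pyridin-3-yl)methoxy group leaves and isopropylcarbamoyl enters. With nothing comparable to lean on, a step larger than the scatter toward a higher number is expected, since compound 2 holds the lowest value seen and a wholly different group now sits at that position. Compound 3 is expected to give 3 uM in this assay, within 0.5 uM to 20 uM, which means an estimated step of a 5.7-fold higher number from compound 2 to compound 3 (0.75 log units; beyond the scatter).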

Compound 3, minimum effective concentration: 15.6 uM
Estimate against measurement, compound 3: 5.2-fold (0.72 log units) below; the measured number falls inside the stated range.
By their numbers in this assay, from the lowest: compound 2; then compound 1; then compound 3.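

The earlier pair changed only the ring at the end of the chain, whereas compound 3 replaces the whole group on this aromatic carbon, and that costs far more in this assay: the change gives a 29-fold higher number from compound 2 to compound 3 (1.47 log units; beyond the scatter) and, measured against the benzyloxy group, a 9.4-fold higher number from compound 1 to compound 3 (0.97 log units; beyond the scatter) as well. This aromatic carbon is therefore not indifferent to what it carries, and among these three compounds the two with a ring-bearing ether group give lower numbers than the one with isopropylcarbamoyl, which has no ring. The size of the rise also shows that swapping the whole group can move the number further than exchanging phenyl for pyridin-3-yl did. Nothing measured here explains why the number rises.

The ether oxygen, the ring and the chain all leave together while the amide enters, so these compounds cannot show which of these changes drives the rise. A benzylcarbamoyl group, which would keep a ring on an amide, or a plain methoxy group, which would keep the oxygen without a ring, could each separate these parts at this aromatic carbon.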